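Swapping propanoylamino for fluoro on a shared core

The source may report more compounds than this note shows. Statements on the series, on what has been measured and on what is new or still open speak of the compounds shown alone.

This account follows three measured compounds and one that has not yet been tested. Compound 1 `CCC(=O)Nc1ccc(-c2nc3cc(C(F)(F)F)ccc3n2C2CCCCC2)cc1`, compound 2 `CCC(=O)Nc1ccc(-c2nc3cc(C(F)(F)F)ccc3[nH]2)cc1` and compound 3 `CCC(=O)Nc1ccc(-c2nc3ccccc3[nH]2)cc1` were each assessed in an ADME assay on Vero cells (Chlorocebus sabaeus) for cytotoxicity; a higher number here means that more compound is tolerated, a lower number that less compound is tolerated. In this assay compound 1 gives > 100000 nM, which is a limit of the assay rather than a number. Compound 2 gives > 100000 nM in this assay, again a limit. Compound 3 gives > 100000 nM in this assay, also a limit. Because (the limit of > 100000 nM in this assay, at which 3 of the 3 values shown sit), compound 2 stands at the same limit as both of its neighbours, and the steps a step that the two limits leave unreadable from compound 1 to compound 2 and a step that the two limits leave unreadable from compound 2 to compound 3 cannot be sized.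

Compound 4 `Fc1ccc(-c2nc3cc(C(F)(F)F)ccc3[nH]2)cc1` differs from compound 2 in one place: fluoro in place of propanoylamino on an aromatic carbon. For the measured compounds named here, neither measured step involves the propanoylamino group, so no measured step bears directly on this change, and the two that exist are themselves unreadable. With every measured value sitting at the limit, compound 4 is expected to remain there too, a step of a number no higher from compound 2 to compound 4 (the limit leaves the size open) of no size beyond the scatter. Compound 4 is therefore estimated at 100000 nM in this assay, within a range from 40000 nM to 250000 nM.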

Compound 4, half-maximal cytotoxic concentration: 60000 nM
The estimate for compound 4 lay 1.7-fold (0.22 log units) above the measured number; the range from low to high includes it.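

In this assay, for the compounds shown here, the step to fluoro at this place, on an aromatic carbon para to a large group, gives an at least 1.6-fold lower number from compound 2 to compound 4 (0.22 log units; that floor lies within the scatter), and compound 4 gives 60000 nM, the first value that is a number rather than a limit. Going by these compounds alone, this shows only that the change can bring a compound into the readable range, not that it lowers the number beyond the scatter, and the earlier steps cannot be read at all. The true size of the step stays unknown because compound 2 is known only as a limit: the limit of > 100000 nM in this assay, at which 3 of the 4 values shown sit.

Open, on these data alone, is what an amine, a carboxylic acid or a longer chain would give at this place. Also open, as far as these compounds go, is whether fluoro would have the same outcome on the core of compound 1 or compound 3.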